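Anilino for phenyl on the imine carbon of compound 2

The source may hold more compounds than are shown below. What is called first, only, known or untested is meant among the compounds shown, and "the series" means these compounds.

Of the compounds shown here, two sharing one core have been tested in a functional assay on the whole organism (strain albino) for inhibition, with Rattus norvegicus as the target, read by paw edema, with a stated time of 1 h, at a dose of 20 mmol/kg by the intraperitoneal route; a lower number here means less inhibition, a higher number more inhibition at the dose given (going by the name of the read-out). Compound 1 `N#CC1=C(NCC(=O)N2CCCC2)N(c2ccccc2)C(=O)N2CCCCC(N3CCCC3)C12` gives 40.1%. Compound 2 `N#CC1=C(/N=C/c2ccccc2)N(c2ccccc2)C(=O)N2CCCCC(N3CCCC3)C12` gives 46.5%. The change from compound 1 to compound 2 replaces the group on a double-bonded ring carbon, and the result was a number 6.4 percentage points higher from compound 1 to compound 2 (within the scatter), so the two compounds sit within the scatter of each other and compound 2 cannot be set apart from compound 1 on these numbers.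

Compound 3 `N#CC1=C(/N=C/Nc2ccccc2)N(c2ccccc2)C(=O)N2CCCCC(N3CCCC3)C12` is not yet measured. Its change from compound 2 is anilino in place of phenyl on a carbon with a double bond to nitrogen. Among the compounds with values here, only the step from compound 1 to compound 2 bears on it, and that step stayed within the scatter. With one neutral precedent and nothing else to go on, no step beyond the scatter is expected in this assay, and the estimated step is a number 1.5 percentage points lower from compound 2 to compound 3 (within the scatter). Compound 3 is therefore expected to give about 45%, within 30% to 60%.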

Compound 3, a percentage reported as inhibition, in the whole organism at one dose (the size of the read-out at that dose, not a potency): 35.2%
Compound 3: middle estimate off by 9.8 percentage points, on the high side; low and high end bracket the measured number.
By their numbers in this assay, from the lowest: compounds 3, 1 and 2 (each within the scatter of the next, the first and the last beyond it).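

In this assay, within the data shown here, the carbon with a double bond to nitrogen is the first place where a single change carries the read-out beyond the scatter: anilino in place of phenyl gives a number 11.3 percentage points lower from compound 2 to compound 3 (beyond the scatter) at this dose. The enlarged group also does not separate compound 3 from compound 1, with a number 4.9 percentage points lower from compound 1 to compound 3 (within the scatter) as the step between them, so the change to anilino sets compound 3 apart only from compound 2. What the entering group adds is one nitrogen and one hydrogen-bond donor, but no measurement at hand ties the lower number to either of them.

On these data alone, whether a benzylamino or a morpholino group on that carbon would stay with compound 2 or fall with compound 3 remains open. Also open, as far as these compounds go, is whether a methoxy group on the aromatic ring of the anilino group would move the number at all.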